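Methyl-for-hydrogen steps and lipophilicity across two cores

The source may report more compounds than this note shows. Statements on the series, on what has been measured and on what is new or still open speak of the compounds shown alone.

Measured so far:
compound 1 `CCN(CCn1cc[n+](C)c1/C=N/O)S(=O)(=O)c1ccccc1` gives -1.39 in a physicochemical assay for lipophilicity; a lower number here means a more polar compound, a higher number a more lipophilic compound
compound 2 `CCCN(CCn1cc[n+](C)c1/C=N/O)S(=O)(=O)c1ccccc1` gives -0.94
compound 3 `C[n+]1ccn(CCCS(C)(=O)=O)c1/C=N/O` gives -2.7

Compound 3 has the lowest number of the three; its gaps to compound 1 and to compound 2 both lie beyond the scatter. The difference between the core of compound 3 and the core of compound 1 is not broken down here. From compound 1 to compound 2 the change is methyl in place of hydrogen on a saturated chain carbon, two bonds along the chain from a sulfonamide nitrogen, and a number 0.45 log units higher from compound 1 to compound 2 (beyond the scatter). Compound 4 `CC[n+]1ccn(CCCS(C)(=O)=O)c1/C=N/O` is not yet measured; it differs from compound 3 by methyl in place of hydrogen on a saturated chain carbon bound to an aromatic nitrogen. This is the same kind of change, but at a different place: in the first pair the carbon is two bonds along the chain from a sulfonamide nitrogen, in the second it is bound to an aromatic nitrogen. Among the compounds with values here, a step of similar size is expected, a number 0.40 log units higher from compound 3 to compound 4 (beyond the scatter), because a number 0.45 log units higher from compound 1 to compound 2 (beyond the scatter) is the only measured step of this kind. Compound 4 is therefore estimated at -2.3 in this assay, expected between -2.7 and -1.9.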

Compound 4, distribution coefficient: -2.6
For compound 4 the middle estimate is 0.30 log units above the measured one, and the stated range covers the measured number.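

In this assay, the new step reads a number 0.10 log units higher from compound 3 to compound 4 (within the scatter), whereas the same kind of change on the core of compound 1 reads a number 0.45 log units higher from compound 1 to compound 2 (beyond the scatter). The step seen on that core therefore did not carry over to this pair, but the two pairs differ in both core and place of the change, so they do not show which of the two matters, and one pair on each side sets no rule for the series. Nothing available bears on the reason for this result.

The compounds shown leave open what a longer chain at the carbon bound to an aromatic nitrogen would give on the core of compound 3. They also leave open how an amine at that place would read in this assay.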